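The source may hold more compounds than are shown below. What is called first, only, known or untested is meant among the compounds shown, and "the series" means these compounds.

Compound 1 `COc1ccc(C2CC(c3ccc(Br)cc3)=NN2C(=O)c2ccc3c(c2)OCCO3)cc1` and compound 2 `O=C(c1ccc2c(c1)OCCO2)N1N=C(c2ccccc2)CC1c1cccc(F)c1` share one core and were both tested in a functional assay on WM 266-4 cells (Homo sapiens) for inhibition, read by MTT assay, with a stated time of 24 h; on this read-out higher numbers stand for weaker inhibition of growth and lower numbers for stronger inhibition of growth. In this assay compound 1 gives 5680 nM, while compound 2 gives 1840 nM. Compound 2 therefore holds the lower of the two numbers, and the gap up to compound 1 lies beyond the usual scatter. Compound 3 `COc1ccc(C2CC(c3ccccc3)=NN2C(=O)c2ccc3c(c2)OCCO3)cc1` has not been measured. It differs from compound 2 in a single place: 4-methoxyphenyl in place of 3-fluorophenyl on a saturated ring carbon. Compound 1 carries the same 4-methoxyphenyl at that carbon, but it also differs from compound 3 in the bromine on its other aryl group, so its number cannot simply be carried over. The step of a 2.2-fold higher number from compound 2 to compound 3 (0.34 log units; beyond the scatter) is expected to run toward weaker inhibition, moderate in size, because compound 1 gives 5680 nM while bearing the same 4-methoxyphenyl. Compound 3 is thus estimated at 4000 nM, within a range from 1500 nM to 10000 nM.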

Compound 3, concentration for 50% growth inhibition: 8370 nM
Compound 3: middle estimate off by 2.1-fold (0.32 log units), on the low side; measured number inside the range.
By their numbers in this assay, from the lowest: compound 2; then compounds 1 and 3 (each within the scatter of the next).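

In this assay, the saturated ring carbon now has a comparison that differs in one place only: (a 4.5-fold higher number from compound 2 to compound 3 (0.66 log units; beyond the scatter)) shows that 4-methoxyphenyl in place of 3-fluorophenyl gives weaker inhibition of growth, beyond the scatter. The bromo group on the other aryl ring, which could not be separated from this change before, gives no readable shift with 4-methoxyphenyl at that carbon (a 1.5-fold higher number from compound 1 to compound 3 (0.17 log units; within the scatter)), a step within the scatter. Nothing in the data explains either step.

Going by these compounds, it remains open whether the step follows the methoxy group or the ring position it occupies, and what 3-methoxyphenyl or 4-fluorophenyl would give on the same carbon. Also open, on these data alone, is whether bromo would remain equally silent alongside 3-fluorophenyl, and how an aminophenyl group would behave at this carbon.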